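Chloro for hydrogen on a pendant phenyl ring

The source may report more compounds than this note shows. Statements on the series, on what has been measured and on what is new or still open speak of the compounds shown alone.

Compound 1 `COc1cc(/C=C/C(=O)c2cccc(-n3cc(-c4ccccc4)[nH]c3=O)c2)ccc1O` was tested in a functional assay on SK-OV-3 cells (Homo sapiens) for inhibition (on this read-out higher numbers stand for weaker inhibition of growth and lower numbers for stronger inhibition of growth), where compound 1 gives 3760 nM. Among the three measured compounds it holds the second highest number: compound 2 `COc1cc(/C=C/C(=O)c2cccc(-n3cc(-c4ccccc4)[nH]c3=O)c2)cc(OC)c1OC` gives 3270 nM and compound 3 `COc1cc(/C=C/C(=O)c2cccc(-n3cc(-c4cc(OC)c(OC)c(OC)c4)[nH]c3=O)c2)cc(OC)c1OC` gives 5120 nM, both within the scatter of compound 1. Among the compounds with values here, the one single-point step among them, a 1.6-fold higher number from compound 2 to compound 3 (0.19 log units; within the scatter), stayed within the scatter. Compound 4 `COc1cc(/C=C/C(=O)c2cccc(-n3cc(-c4ccc(Cl)cc4)[nH]c3=O)c2)ccc1O` differs from compound 1 by chloro in place of hydrogen on an aromatic carbon. Within the data shown here, no measured step exchanges hydrogen for chloro, and the only step that alters this pendant ring left this assay within the scatter, so nothing in the data points to a sizeable move. Compound 4 is therefore expected to show a 1.1-fold lower number from compound 1 to compound 4 (0.03 log units; within the scatter), with an estimate of 3500 nM spanning 1200 nM to 10000 nM.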

Compound 4, concentration for 50% growth inhibition: 3190 nM
Compound 4: middle estimate off by 1.1-fold (0.04 log units), on the high side; the range from low to high includes it.
By their numbers in this assay, from the lowest: compounds 4, 2, 1 and 3 (each within the scatter of the next).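

The step from phenyl to 4-chlorophenyl gives a 1.2-fold lower number from compound 1 to compound 4 (0.07 log units; within the scatter) in this assay and thus shows that a chloro para to a large group on this pendant ring leaves the read-out within the scatter. Alongside a 1.6-fold higher number from compound 2 to compound 3 (0.19 log units; within the scatter) this is a second change on this ring that stays within the scatter, here on the parent with the simpler substituted styryl end. Nothing measured here speaks to the reason for this result. Still open, as far as these compounds go, is whether an amine or a carboxylic acid in place of the chloro would move the number beyond the scatter.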